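Ring swap on the amide of compound 2

A few compounds are considered here, and "the series" means these few. Any claim that something is new, unique, unknown or untested is made for them only; others in the source may bear on it.

Going by the values given here, the series so far holds two measured compounds, compound 1 `CNC(=O)c1cc(C(=O)NC2CC2)cc2c1OC[C@H]2c1cccc2[nH]ccc12` and compound 2 `CNC(=O)c1cc(C(=O)N[C@H]2[C@@H]3C[C@H](O)C[C@@H]32)cc2c1OC[C@@]2(C)c1ccccc1`, both read in a physicochemical assay for solubility; on this read-out higher numbers stand for higher solubility and lower numbers for lower solubility. Compound 1 gives >= 142 ug/mL, which is a limit of the assay and not a number. Compound 2 gives >= 151 ug/mL, which is likewise a limit and not a number. Neither compound has an exact reading, so the two cannot be ranked.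

Compound 3 `CNC(=O)c1cc(C(=O)N[C@H]2CC[C@H](O)CC2)cc2c1OC[C@@]2(C)c1ccccc1` keeps the shared core of compound 2 and changes one group: a group of 7 heavy atoms (6 carbon, 1 oxygen; one six-membered non-aromatic ring of carbon only) in place of a group of 7 heavy atoms (6 carbon, 1 oxygen; one three-membered non-aromatic ring of carbon only, one five-membered non-aromatic ring of carbon only), on an amide-type nitrogen. The entering group is 4-hydroxycyclohexyl, on an amide-type nitrogen.

Among the compounds with values here, no step between measured compounds is available to calibrate this change. The leaving and entering groups have matching counts of heavy atoms, donors and acceptors, so no step beyond the scatter is expected in this assay, and neither direction is favoured. The expected step is an at least 1.0-fold lower number from compound 2 to compound 3 (0.03 log units; that floor lies within the scatter). For compound 3 the estimated value is 140 ug/mL, with an expected range of 70 ug/mL to 190 ug/mL.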

Compound 3, solubility: >= 161 ug/mL
Compound 3 was reported as a limit (the forecaster's own chance of this, stated with the estimate: 60%); middle value at least 1.1-fold (0.06 log units) away from the limit.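

In this assay compound 3 gives >= 161 ug/mL, which is a limit and not a number. Going by these compounds alone, compound 2 gives >= 151 ug/mL, also a limit, so no step to compound 3 can be read. Whether 4-hydroxycyclohexyl on the amide-type nitrogen changes the reading in this assay, and in which direction, stays open; none of the compounds shown has an exact reading.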